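The compounds below may be only part of what the source reports. "The series", "measured", "known", "first", "only" and "open" are said of these compounds alone.

Among the compounds with values here, compound 2 `CC1=C(N2CC2)C(=O)C(CC(C)OC(N)=O)=C(N2CC2)C1=O` gives the higher of the two values so far in a functional assay on L1210 cells (Mus musculus), with a stated time of 1 days (a higher number here means a more potent compound, by a factor of ten per unit of this negative logarithm, a lower number a less potent compound), namely 5.18; compound 1 `CCCC1=C(N2CC2)C(=O)C(C(COC(N)=O)OC)=C(N2CC2)C1=O` gives 4.64 in this assay, a gap beyond the usual scatter. Compound 3 `CC1=C(N2CC2)C(=O)C(CCCOC(N)=O)=C(N2CC2)C1=O` holds the same atoms as compound 2, joined differently: a group of 6 heavy atoms (3 carbon, 1 nitrogen, 2 oxygen; no ring) in place of a group of 6 heavy atoms (3 carbon, 1 nitrogen, 2 oxygen; no ring), on a saturated chain carbon bound to a double-bonded ring carbon, with 2-(carbamoyloxy)ethyl entering on a saturated chain carbon bound to a double-bonded ring carbon. Within the data shown here, no measured pair shows the effect of such a rearrangement, so the step is expected to be small, at most a slight drop within the scatter, a number 0.18 log units lower from compound 2 to compound 3 (within the scatter). Compound 3 is accordingly estimated at 5, between 4.5 and 5.5 in this assay.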

Compound 3, logarithm of the reciprocal of the active concentration, log(1/C): 5.48
Compound 3: middle estimate off by 0.48 log units, on the low side; measured number inside the range.
By their numbers in this assay, from the lowest: compound 1; then compounds 2 and 3 (each within the scatter of the next).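

With 2-(carbamoyloxy)ethyl entering on a saturated chain carbon bound to a double-bonded ring carbon, the same atoms joined differently give a number 0.30 log units higher from compound 2 to compound 3 (within the scatter) in this assay. At this position, this rearrangement therefore separates the two compounds by no more than repeated measurements would. Nothing available bears on the reason for this result. The compounds shown leave open whether a longer chain bearing the carbamoyloxy group, or an amine in its place, would hold the potency at this position.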